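Carbamate in Place of Prolinamide on a Sulfonyl Tetrahydronaphthalene Scaffold

The source may hold more compounds than are shown below. What is called first, only, known or untested is meant among the compounds shown, and "the series" means these compounds.

Compound 1 `NC[C@@H]1CCCc2cc(S(=O)(=O)c3c[nH]c4ccccc34)ccc21`: 0.0501 nM
Compound 2 `O=C(NC[C@@H]1CCCc2cc(S(=O)(=O)c3cccc(F)c3)ccc21)[C@H]1CCCN1`: 0.631 nM

In an assay on isolated protein for displacement of a labelled ligand from 5-hydroxytryptamine receptor 6 (Homo sapiens) (on this read-out higher numbers stand for weaker inhibition and lower numbers for stronger inhibition), compound 1 gives 0.0501 nM and compound 2 gives 0.631 nM. Compound 2 therefore stands as the highest of the two numbers, beyond the scatter from compound 1. Compound 3 `COC(=O)NC[C@@H]1CCCc2cc(S(=O)(=O)c3cccc(F)c3)ccc21` differs from compound 2 only in one place: methoxy in place of pyrrolidin-2-yl on a carbonyl carbon. Among the measured compounds shown here, no step between measured compounds bears on this change. The step from compound 2 to compound 3 is expected to be a 4.8-fold higher number from compound 2 to compound 3 (0.68 log units; beyond the scatter), towards weaker inhibition. For compound 3 the estimated value in this assay is 3 nM, within the range 0.6 nM to 15 nM.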

Compound 3, inhibition constant: 1.59 nM
For compound 3 the middle estimate is 1.9-fold (0.28 log units) above the measured one; measured number inside the range.
By their numbers in this assay, from the lowest: compound 1; then compound 2; then compound 3.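

In this assay, methoxy in place of pyrrolidin-2-yl on a carbonyl carbon gives a 2.5-fold higher number from compound 2 to compound 3 (0.40 log units; beyond the scatter), a modest step that lies beyond the scatter. At this position, then, the five-membered ring, its defined stereocentre and its hydrogen-bond donor can all leave at only a modest cost in binding. No available evidence accounts for the size of this step.

From the compounds shown here alone, how an ethoxy or a dimethylamino group on the same carbonyl carbon would read remains open. So does whether a step of this size would hold with the sulfonyl substituent of compound 1.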